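Chain extension on two pyrazolone cores; expected effect of the change

A few compounds are considered here, and "the series" means these few. Any claim that something is new, unique, unknown or untested is made for them only; others in the source may bear on it.

Measured compounds:
compound 1, `CCCC(=O)c1c(C)nn(CCCN2CCN(c3ccc(C)cc3)CC2)c(=O)c1N`, 25%
compound 2, `CCCCC(=O)c1c(C)nn(CCCN2CCN(c3ccc(C)cc3)CC2)c(=O)c1N`, 23%
compound 3, `C=Cc1c(CC)nn(CCCN2CCN(c3ccc(C)cc3)CC2)c(=O)c1N`, 0%

In a functional assay on the whole organism (Abdomen, strain Swiss) for inhibition, with Mus musculus as the target, with stated times of 30 min, 10 min and 5 min, at a dose of 20 mg/kg by the oral route (a higher number here means a stronger effect of the compound at the dose given, a lower number a weaker effect), compound 1 gives 25%. Compound 2 carries methyl in place of hydrogen on a saturated chain carbon, three bonds along the chain from a carbonyl carbon and in this assay compound 2 gives 23%; the step of a number 2 percentage points lower from compound 1 to compound 2 (within the scatter) is within the scatter, so the two values show no change that can be read.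

Compound 3 has a different core; the difference between the two cores is not broken down here. In this assay compound 3 gives 0%, the lowest number of the three and beyond the scatter from compound 1 and from compound 2.

Compound 4, `C=Cc1c(CCC)nn(CCCN2CCN(c3ccc(C)cc3)CC2)c(=O)c1N`, is not yet measured. It differs from compound 3 by methyl in place of hydrogen on a saturated chain carbon, two bonds along the chain from an aromatic carbon. This is the same kind of change as from compound 1 to compound 2, but the place differs: there the methyl enters three bonds along the chain from a carbonyl carbon, here two bonds along the chain from an aromatic carbon. Among the measured compounds shown here, only one earlier instance exists, and it rests on the other core. Given that the earlier step of a number 2 percentage points lower from compound 1 to compound 2 (within the scatter) lay within the scatter, the step from compound 3 to compound 4 is expected to be small, about a number 3 percentage points higher from compound 3 to compound 4 (within the scatter). Compound 4 is therefore estimated at 3%, between 0% and 15%, leaving it close to compound 3.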

Compound 4, a percentage reported as inhibition, in the whole organism at one dose (the size of the read-out at that dose, not a potency): 7%
Beside the measured number, compound 4's estimate is 4 percentage points below it; low and high end bracket the measured number.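

In this assay, methyl in place of hydrogen on a saturated chain carbon, two bonds along the chain from an aromatic carbon, gives a number 7 percentage points higher from compound 3 to compound 4 (within the scatter). Set beside the earlier step, the change reads alike on the two cores: the same change on two cores in this assay, a number 2 percentage points lower (within the scatter) from compound 1 to compound 2 and a number 7 percentage points higher (within the scatter) from compound 3 to compound 4, 9 percentage points apart, within the scatter of two such steps. This shows no readable effect of the added methyl on either core, but it rests on a single pair per core, the methyl enters at a different place in each pair, and two steps inside the scatter cannot show that a real effect carries from one core to the other.

Open, going by these compounds, is whether a longer chain at this place, or an amine or a carboxylic acid at the chain end, would move the read-out beyond the scatter on either core. Also open, on these data alone, is how these pairs would compare at other doses, since the read-out gives the size of the effect at one dose and not a potency.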